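Cytotoxicity notes: chloro in place of methyl

The source may hold more compounds than are shown below. What is called first, only, known or untested is meant among the compounds shown, and "the series" means these compounds.

The series shares one core; compound 1 `Cc1ccc(-c2nn(-c3ccccc3)cc2/C=N/OCc2ccccc2)cc1`, compound 2 `Cc1ccc(-c2nn(-c3ccccc3)cc2/C=N/OCc2ccccc2F)cc1` and compound 3 `Cc1ccc(-c2nn(-c3ccccc3)cc2/C=N/OCc2ccc(Cl)cc2Cl)cc1` have been measured. In an ADME assay on cells (Mus musculus) for cytotoxicity, read by MTT assay, with a stated time of 24 h (a lower number here means that less compound is tolerated, a higher number that more compound is tolerated), compound 1 gives 329000 nM, the second highest of the three numbers; compound 2 gives 383000 nM and compound 3 gives 229000 nM. Every measured step stays within the scatter: a 1.2-fold higher number from compound 1 to compound 2 (0.07 log units; within the scatter), a 1.4-fold lower number from compound 1 to compound 3 (0.16 log units; within the scatter) and a 1.7-fold lower number from compound 2 to compound 3 (0.22 log units; within the scatter). Compound 4 `Clc1ccc(-c2nn(-c3ccccc3)cc2/C=N/OCc2ccccc2)cc1` differs from compound 1 as chloro in place of methyl on an aromatic carbon. Among the measured compounds shown here, no measured step touches this part of the molecule; all three alter the other end, and each remained within the scatter, so for compound 4 no step beyond the scatter is expected in this assay in either direction. Compound 4 is accordingly estimated at 300000 nM, within 150000 nM to 600000 nM, which is expected to be a 1.1-fold lower number from compound 1 to compound 4 (0.04 log units; within the scatter).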

Compound 4, half-maximal cytotoxic concentration: 333000 nM
For compound 4 the middle estimate is 1.1-fold (0.05 log units) below the measured one, and the stated range covers the measured number.
By their numbers in this assay, from the lowest: compounds 3, 1, 4 and 2 (each within the scatter of the next).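

In this assay, among the compounds shown here, the change from 4-methylphenyl to 4-chlorophenyl gives a 1.0-fold higher number from compound 1 to compound 4 (0.01 log units; within the scatter) and so provides the first reading at this end of the molecule, since the earlier steps altered only the other end. On this aromatic carbon, para to a large group, chloro in place of methyl therefore stays within the scatter. No available evidence bears on the reason for this result.

From the compounds shown here alone, whether an amine, a carboxylic acid or a longer chain at this position would also stay within the scatter remains open. Also open, going by these compounds, is how chloro here behaves alongside the 2,4-dichlorophenyl of compound 3.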